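Propoxy to isobutoxy on a shared enol core

This account rests on a few compounds, and the source may have more. Where it says the series, first, only, none or still open, it means among the compounds named here.

Within the data shown here, compound 1 `CCCOC1=C(CCC)C(=O)/C(=C(O)/C=C/c2ccccc2)C(=O)C1(CCC)CCC` carries the only number in this set; in a functional assay on 1A9 cells (Homo sapiens) for antiproliferative activity, read by sulforhodamine B assay, with a stated time of 3 days (a higher number here means that more compound is needed for the effect, a lower number that less compound is needed), compound 1 gives 2 uM. Compound 2 `CCCC1(CC=C(C)C)C(=O)C(C(=O)/C=C/c2ccccc2)=C(O)C(CCC)(CCC)C1=O` was examined, but in this assay compound 2 stands with "not determined" (no result reported), so it adds nothing to the count. Compound 3 `CCCC1=C(OCC(C)C)C(CCC)(CCC)C(=O)/C(=C(O)\C=C\c2ccccc2)C1=O` differs from compound 1 in one place: methyl in place of hydrogen on a saturated chain carbon bound to two saturated chain carbons. Among the measured compounds shown here, no measured pair in the set shows this change, so there is no step to lean on. One added methyl on a saturated chain carbon is expected to give a step of no change at the digits printed from compound 1 to compound 3 (within the scatter) that stays within the scatter. Compound 3 is therefore expected near 2 uM, with a range from 0.7 uM to 6 uM.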

Compound 3, concentration for half-maximal effect: 6.9 uM
The estimate for compound 3 lay 3.5-fold (0.54 log units) below the measured number; the whole stated range lies below it.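

Propoxy to isobutoxy is not a silent change at this position: in this assay the added methyl on a saturated chain carbon bound to two saturated chain carbons gives a 3.5-fold higher number from compound 1 to compound 3 (0.54 log units; beyond the scatter) and thus a modest step beyond the scatter. Among these compounds, this is the only reading of a change here, and it rests on a single pair. Nothing available explains the step.

Open, as far as these compounds go, is whether a shorter ethoxy or a longer butoxy chain moves the number the same way, and what a terminal amine on the propoxy chain would do.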